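The compounds below may be only part of what the source reports. "The series", "measured", "known", "first", "only" and "open" are said of these compounds alone.

Measured so far:
- Compound 1 `CC(=O)N1N=C(c2ccc3ccccc3c2)OC1c1ccccc1`: 2.57 ug/mL
- Compound 2 `COc1ccc(C2OC(c3ccc4ccccc4c3)=NN2C(C)=O)cc1`: 6.86 ug/mL
- Compound 3 `CC(=O)N1N=C(c2ccc3ccccc3c2)OC1c1cccc(Br)c1`: 2.36 ug/mL

In a functional assay on B16-F10 cells (Mus musculus) for antiproliferative activity, read by MTT assay, with a stated time of 48 h (on this read-out higher numbers stand for weaker inhibition and lower numbers for stronger inhibition), compound 1 gives 2.57 ug/mL, the second highest of the three numbers. It lies within the scatter of compound 3, while compound 2 stands furthest from it.

The next compound is compound 4 `CC(=O)N1N=C(c2ccc3ccccc3c2)OC1c1ccc(Cl)cc1`, related to compound 1 by chloro in place of hydrogen on an aromatic carbon. In words, this is chloro in place of hydrogen on an aromatic carbon, turning phenyl into 4-chlorophenyl.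

Among the compounds with values here, no chloro compound has been measured, so two steps serve as guides. The nearest is the bromo change, a 1.1-fold lower number from compound 1 to compound 3 (0.04 log units; within the scatter), although it gives 3-bromophenyl rather than a 4-substituted phenyl. The methoxy change, a 2.7-fold higher number from compound 1 to compound 2 (0.43 log units; beyond the scatter), does give a 4-substituted phenyl, but the entering group is of a different kind. The step of a 2.9-fold lower number from compound 2 to compound 3 (0.46 log units; beyond the scatter) combines these same two changes and adds nothing independent.

More weight goes to the halogen precedent, so no step beyond the scatter is expected in this assay, with a slight drift towards a higher number allowed for. The expected step is a 1.1-fold higher number from compound 1 to compound 4 (0.04 log units; within the scatter).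

For compound 4 the estimated value is 2.8 ug/mL, with an expected range of 1.3 ug/mL to 6 ug/mL.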

Compound 4, half-maximal inhibitory concentration: 2.48 ug/mL
Estimate against measurement, compound 4: 1.1-fold (0.05 log units) above; the measured number falls inside the stated range.
By their numbers in this assay, from the lowest: compounds 3, 4 and 1 (each within the scatter of the next); then compound 2.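

In this assay, within the data shown here, chloro on an aromatic carbon, para to a large group, gives no step beyond the scatter (a 1.0-fold lower number from compound 1 to compound 4 (0.02 log units; within the scatter)), so this place, previously seen only with methoxy, now has a substituent that leaves the number level with hydrogen. The two halogen-bearing compounds also cannot be told apart (a 1.1-fold higher number from compound 3 to compound 4 (0.02 log units; within the scatter)), so 4-chlorophenyl and 3-bromophenyl read alike here, and both stay within the scatter of the plain phenyl of compound 1. The higher number seen with 4-methoxyphenyl is therefore not shared by every group at this place, as the exchange of methoxy for chloro shows a modest step beyond the scatter (a 2.8-fold lower number from compound 2 to compound 4 (0.44 log units; beyond the scatter)).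

No measurement in hand accounts for the difference between methoxy and chloro at this place. Still open, from the compounds shown here alone, is whether an amine, a carboxylic acid or a longer alkoxy chain on this aromatic carbon would follow chloro or methoxy, and whether chloro and bromo would still read alike if compared on the same ring carbon.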